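This account rests on a few compounds, and the source may have more. Where it says the series, first, only, none or still open, it means among the compounds named here.

Compound 2 `CC(C)c1cc(C(=O)N(c2ccc(NC(=O)CCCCCCC(=O)NO)cc2)C(C)C)c(O)cc1O` is the point of departure for this step. In a functional assay on A549 cells (Homo sapiens) for inhibition, read by sulforhodamine B assay, with a stated time of 48 h (on this read-out lower numbers stand for stronger inhibition of growth and higher numbers for weaker inhibition of growth), compound 2 gives only a limit, > 10000 nM, and no number. Compound 3 `CC(C)c1cc(C(=O)Nc2ccccc2NC(=O)CCCCCCC(=O)NO)c(O)cc1O` likewise gives only a limit in this assay, > 10000 nM. Compound 2 stands at the limit of > 10000 nM in this assay, at which 2 of the 3 values shown sit, alongside compound 3. Within the data shown here, compound 1 `CCN(C(=O)c1cc(C(C)C)c(O)cc1O)c1cccc(NC(=O)CCCCCCC(=O)NO)c1` is the one member of the set with a number: in this assay compound 1 gives 1590 nM. The unmeasured compound 4 `CC(C)c1cc(C(=O)N(C)c2ccc(NC(=O)CCCCCCC(=O)NO)cc2)c(O)cc1O` is reached from compound 2 by a single change, (methyl in place of isopropyl on an amide-type nitrogen). Among the measured compounds shown here, no pair of measured compounds differs in one place only, so there is no measured step to lean on. The value of compound 2 is a limit, so any move toward stronger inhibition would first have to bring compound 4 into the range where a number is reported at all. Compound 4 is expected to give about 5000 nM in this assay, within 1200 nM to 20000 nM. The expected step is an at least 2.0-fold lower number from compound 2 to compound 4 (0.30 log units; that floor lies within the scatter), toward stronger inhibition, though the chance remains that the assay again reports only a limit.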

Compound 4, concentration for 50% growth inhibition: 770 nM
For compound 4 the middle estimate is 6.5-fold (0.81 log units) above the measured one; the measured number lies below the stated range.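

In this assay, replacing isopropyl with methyl on the amide-type nitrogen gives an at least 12-fold lower number from compound 2 to compound 4 (1.11 log units; beyond the scatter), so the group on this nitrogen can decide whether a number is reported at all. The step is only a floor, because compound 2 gives a limit and not a number: the limit of > 10000 nM in this assay, at which 2 of the 4 values shown sit. Only carbon leaves and enters at this nitrogen, with no ring, charge, hydrogen-bond donor or hydrogen-bond acceptor involved in the change.

Compound 1 carries a different group on the nitrogen but differs from compound 4 in more than one place, so it does not show how the size of this group relates to growth inhibition. The compounds shown also leave open how a cyclopropyl group, an n-propyl chain or a 2-methoxyethyl chain on this nitrogen would behave.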